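The compounds below may be only part of what the source reports. "The series", "measured", "known", "first", "only" and "open" are said of these compounds alone.

Measured so far:
- compound 1, `O=c1ccn(CCN2CCCCC2)c(CO)c1O`: 9.24
- compound 2, `Cn1cc(O)c(=O)cc1CN1CCCCC1`: 8.86
- compound 3, `CCc1c(O)c(=O)ccn1CCCn1ccnc1`: 9.66

In a physicochemical assay for acid dissociation, read by spectrophotometry, compound 2 gives the lowest of the three numbers. The nearest neighbour is compound 1, whose value in this assay is 9.24, a gap that lies beyond the usual scatter; compound 3 stands furthest away with 9.66, also beyond the scatter. None of these three pairs differ in only one place, so their gaps cannot be tied to a single structural change.

Compound 4, `O=c1cc(CN2CCCCC2)n(CCN2CCCCC2)cc1O`, has not yet been measured in this assay. It is made from compound 2 by one change: (piperidin-1-yl)methyl in place of hydrogen on a saturated chain carbon bound to an aromatic nitrogen. Within the data shown here, no single-point step of this kind is available among the measured compounds, so the expectation rests on the spread seen above. A small downward step is expected, a number 0.26 log units lower from compound 2 to compound 4 (within the scatter), about the size of the gap between compound 1 and compound 2 rather than anything larger. On that basis compound 4 is estimated to give 8.6 in this assay, with a plausible range from 8.2 to 9.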

Compound 4, acid dissociation constant: 8.95
Compound 4: middle estimate off by 0.35 log units, on the low side; measured number inside the range.
By their numbers in this assay, from the lowest: compounds 2, 4 and 1 (each within the scatter of the next, the first and the last beyond it); then compound 3.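

In this assay, (piperidin-1-yl)methyl in place of hydrogen on a saturated chain carbon bound to an aromatic nitrogen gives a number 0.09 log units higher from compound 2 to compound 4 (within the scatter). Among these compounds, this is the first gap in the set that can be tied to a single structural change, and it shows that adding 7 heavy atoms, including a six-membered non-aromatic ring, at this place leaves the number within the usual scatter. No measurement shown here explains why the number stays within the scatter.

Going by these compounds, it remains open whether a different group at this place, such as a carboxylic acid or a morpholine ring, would also stay within the scatter. On these data alone, it is also open whether the same change would give a similarly small step on the cores of compound 1 and compound 3.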